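Chloro and methyl moved on the sulfonamide aryl ring

A few compounds are considered here, and "the series" means these few. Any claim that something is new, unique, unknown or untested is made for them only; others in the source may bear on it.

Compound 2 `Cc1ccc(NS(=O)(=O)c2ccc(-c3cnc(C4CC4)o3)cc2)cc1C` and compound 1 `Cc1cc(NS(=O)(=O)c2ccc(-c3cnc(C4CC4)o3)cc2)ccc1Cl` share one core and differ in a single place. In a functional assay on cells (leukaemia cell line, Homo sapiens) for inhibition, read by sulforhodamine B assay, with a stated time of 48 h (a lower number here means that less compound is tolerated, a higher number that more compound is tolerated), compound 1 gives > 100000 nM, which is a limit of the assay rather than a number. In this assay compound 2 likewise gives > 100000 nM, again a limit. Hence a step that the two limits leave unreadable from compound 1 to compound 2; the two values show nothing beyond (the limit of > 100000 nM in this assay, at which 2 of the 2 values shown sit). Compound 2 therefore stands at that limit, without a read number. Compound 3 `Cc1ccc(Cl)c(NS(=O)(=O)c2ccc(-c3cnc(C4CC4)o3)cc2)c1` carries 2-chloro-5-methylphenyl in place of 3,4-dimethylphenyl on a sulfonamide nitrogen. Among the measured compounds shown here, the only measured step that bears on this change is the one from compound 1 to compound 2, whose size cannot be read, so no direction beyond the scatter can be named and the same limit is expected for compound 3. Compound 3 is estimated at 150000 nM, between 50000 nM and 500000 nM. This expectation amounts to a step that the limit leaves unreadable from compound 2 to compound 3.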

Compound 3, concentration lethal to 50% of the cells: > 100000 nM
Compound 3 gave a limit, no number (the forecaster's own chance of this, stated with the estimate: 85%); the middle value lies beyond the limit too.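

No step among compound 1, compound 2 and compound 3 can be read in this assay, as each gives only a limit and no number: the limit of > 100000 nM in this assay, at which 3 of the 3 values shown sit.

The compounds shown leave open whether any group on the sulfonamide nitrogen would give a readable value in this assay.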